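The source may report more compounds than this note shows. Statements on the series, on what has been measured and on what is new or still open speak of the compounds shown alone.

Measured compounds:
compound 1 `CN1CCN(c2nc(Cl)nc3c2ncn3Cc2ccc(C(=O)Nc3ccccc3N)cc2)CC1`, 310 nM
compound 2 `CCC(C)n1cnc2c(NCc3ccc(C(=O)Nc4ccccc4N)cc3)nc(Cl)nc21`, 720 nM
compound 3 `Cc1ccc(Nc2nc(Cl)nc3c2ncn3Cc2ccc(C(=O)Nc3ccccc3N)cc2)cc1`, 580 nM

In a functional assay on HCT-116 cells (Homo sapiens) for antiproliferative activity, read by CCK-8 assay, with a stated time of 72 h (on this read-out higher numbers stand for weaker inhibition and lower numbers for stronger inhibition), compound 1 gives the lowest of the three numbers; compound 3 sits within the scatter of it, and compound 2 lies beyond the scatter. Compound 4 `CC1CCN(c2nc(Cl)nc3c2ncn3Cc2ccc(C(=O)Nc3ccccc3N)cc2)CC1` is not yet measured. It differs from compound 1 in one place: 4-methylpiperidin-1-yl in place of 4-methylpiperazin-1-yl on an aromatic carbon. For the measured compounds named here, the only measured step at that same place is a 1.9-fold higher number from compound 1 to compound 3 (0.27 log units; within the scatter), which swapped in a quite different group and still stayed within the scatter. Going by the values given here, no measured pair exchanges a ring nitrogen for a ring carbon, so the expectation rests on that one step alone. Compound 4 is therefore expected to show a 1.3-fold higher number from compound 1 to compound 4 (0.11 log units; within the scatter), a change not clearly beyond the scatter. The estimate for compound 4 is 400 nM, ranging from 180 nM to 900 nM.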

Compound 4, half-maximal inhibitory concentration: 950 nM
Compound 4: the middle estimate sits 2.4-fold (0.38 log units) below what was measured; the measured number lies above the stated range.
By their numbers in this assay, from the lowest: compounds 1, 3, 2 and 4 (each within the scatter of the next, the first and the last beyond it).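

In this assay, replacing a ring nitrogen of the 4-methylpiperazin-1-yl group with a carbon gives a 3.1-fold higher number from compound 1 to compound 4 (0.49 log units; beyond the scatter), so this position responds even when the six-membered ring and the heavy-atom count stay the same. The 4-methylpiperidin-1-yl and (4-methylphenyl)amino groups cannot be ranked, as the step between them is a 1.6-fold higher number from compound 3 to compound 4 (0.21 log units; within the scatter). Nothing available explains why the ring nitrogen matters here.

On these data alone, it remains open whether a morpholin-4-yl group, with an oxygen in place of that ring nitrogen, would match compound 1. The same question applies to a piperazin-1-yl group without its methyl.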